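The source may report more compounds than this note shows. Statements on the series, on what has been measured and on what is new or still open speak of the compounds shown alone.

Of the compounds shown here, three have so far been measured in an ADME assay (liver) for metabolic stability, with Liver microsome (Homo sapiens) as the target, read by LC-MS, using microsomes and NADPH, with a stated time of 5 min, at 37 degrees C; on this read-out lower numbers stand for slow clearance and higher numbers for fast clearance. Compound 1 `CCn1c([C@@H](C)NS(=O)(=O)c2ccc(Cl)cc2)nc2ccc(CO)cc21` gives 84 mL.min-1.g-1, and compound 2 `CCn1c(C(C)NS(=O)(=O)c2ccc(Cl)cc2)nc2cccnc21` gives 94 mL.min-1.g-1. Compound 3 `CCn1c([C@@H](C)NS(=O)(=O)c2ccc(C#N)cc2)nc2ccc(C(F)(F)F)cc21` gives 34 mL.min-1.g-1, the lowest of the three numbers; its gaps to compound 1 and to compound 2 both lie beyond the usual scatter, so compound 3 is the most slowly cleared of the three. Compound 4 `CCn1ncc(S(=O)(=O)N[C@H](C)c2nc3ccc(C(F)(F)F)cc3n2CC)c1C` has not yet been measured. It differs from compound 3 in a single place: 1-ethyl-5-methyl-1H-pyrazol-4-yl in place of 4-cyanophenyl on a sulfonyl sulfur. For the measured compounds named here, no pair of measured compounds shows this same change, so no measured step tells how such a swap moves clearance. From the numbers alone, compound 3 already sits at the slow end of what has been seen, and a new group on the sulfonyl sulfur is expected to push the number modestly upward rather than downward, though a result within the scatter would not be surprising. The estimate for compound 4 in this assay is 45 mL.min-1.g-1, with a range from 20 mL.min-1.g-1 to 100 mL.min-1.g-1, meaning an expected step of a 1.3-fold higher number from compound 3 to compound 4 (0.12 log units; within the scatter).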

Compound 4, intrinsic clearance in microsomes: > 100 mL.min-1.g-1
Compound 4 was reported as a limit (the forecaster's own chance of this, stated with the estimate: 5%); middle value at least 2.2-fold (0.34 log units) away from the limit.
By their numbers in this assay, from the lowest: compound 3; then compounds 1 and 2 (each within the scatter of the next). At a limit, above all of these: compound 4.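

Compound 4 gives > 100 mL.min-1.g-1 in this assay, and this value is a limit of the assay, not a number. The earlier compounds shown here offered no step between two measured structures, whereas 1-ethyl-5-methyl-1H-pyrazol-4-yl in place of 4-cyanophenyl on a sulfonyl sulfur gives an at least 2.9-fold higher number from compound 3 to compound 4 (0.46 log units; beyond the scatter). With the rest of the molecule unchanged, this single swap moves the clearance reading well beyond the scatter, so the low number of compound 3 does not survive every group at this place.

On these data alone, how far compound 4 lies past the reading stays open: the limit of > 100 mL.min-1.g-1 in this assay, at which 1 of the 4 values shown sits. Also open, as far as these compounds go, is whether the pyrazole with a methyl in place of its ethyl chain, or a phenyl ring carrying a carboxylic acid instead of the nitrile, would stay close to compound 3.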